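Diethylcarbamoyl in place of the urea side group: compound 2 to compound 3

The source may report more compounds than this note shows. Statements on the series, on what has been measured and on what is new or still open speak of the compounds shown alone.

Measured so far in a functional assay with Oryctolagus cuniculus as the target; on this read-out lower numbers stand for stronger inhibition and higher numbers for weaker inhibition:
Compound 1 `COc1ccc(-c2nc(/N=C(\N)N3CCOCC3)sc2-c2ccc(OC)cc2)cc1` gives < 1000 nM as a limit of the assay
Compound 2 `COc1ccc(-c2nc(CNC(=O)N3CCOCC3)sc2-c2ccc(OC)cc2)cc1` gives 660 nM as a number

For the measured compounds named here, compound 2 holds the only number in this assay so far, at 660 nM with no second number to compare it with. Compound 1 stands at < 1000 nM which is a limit and not a number. Going by the values given here, the one measured step is a step that the limit leaves unreadable from compound 1 to compound 2 and it offers no size to carry forward.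

Compound 3 `CCN(CC)C(=O)c1nc(-c2ccc(OC)cc2)c(-c2ccc(OC)cc2)s1` has not been measured. It differs from compound 2 by one change (diethylcarbamoyl in place of (((morpholin-4-yl)carbonyl)amino)methyl on an aromatic carbon) with diethylcarbamoyl in place of (((morpholin-4-yl)carbonyl)amino)methyl on an aromatic carbon. Among the compounds with values here, no measured step speaks to this change. With compound 2 at 660 nM as the sole anchor, no shift beyond the usual scatter is expected in either direction. The expected move is a 1.1-fold higher number from compound 2 to compound 3 (0.03 log units; within the scatter) and it remains an estimate with wide bounds. For compound 3 the estimated value is 700 nM with an expected range from 200 nM to 2500 nM in this assay and the reading itself is still to come.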

Compound 3, half-maximal inhibitory concentration: < 10 nM
Compound 3 was reported as a limit; the forecaster's own chance of this, stated with the estimate: 25%; at least 70-fold (1.84 log units) between middle value and limit.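

In this assay, for the compounds shown here, the aromatic carbon next to the ring nitrogen and next to the ring sulfur turns out to be highly sensitive to the group it carries: diethylcarbamoyl in place of (((morpholin-4-yl)carbonyl)amino)methyl gives an at least 66-fold lower number from compound 2 to compound 3 (1.81 log units; beyond the scatter), the first step at this position whose size can be read, even if only as a minimum. Compound 3 gives < 10 nM, which is a limit of the assay and not a number. The step from compound 1 to compound 3 cannot be read, and nothing measured here bears on the cause of the large step from the urea side group to diethylcarbamoyl.

This single change replaces the whole side group, so the compounds shown do not tell whether the gain follows the carbonyl standing directly on the ring or the loss of the morpholine ring, a question that a morpholin-4-ylcarbonyl or a piperidin-1-ylcarbonyl group on the same carbon could help to separate. As far as these compounds go, it also remains open how much of the gain would survive with a shorter dimethylcarbamoyl group or a longer dipropylcarbamoyl group.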